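Series notes: chlorine position on the carbonyl-side phenyl

The source may hold more compounds than are shown below. What is called first, only, known or untested is meant among the compounds shown, and "the series" means these compounds.

Measured compounds:
Compound 1, `COc1cccc(C(=O)Nc2cc(Sc3ncn[nH]3)c(O)c3ccccc23)c1`: in a functional assay on PC-3 cells (Homo sapiens) for antiproliferative activity, read by MTT assay, with a stated time of 48 h (on this read-out lower numbers stand for stronger inhibition and higher numbers for weaker inhibition), compound 1 gives 42100 nM.
Compound 2, `Cc1nnc(Sc2cc(NC(=O)c3ccc(Cl)cc3)c3ccccc3c2O)s1`: in this assay compound 2 gives 49500 nM.
Compound 3, `O=C(Nc1cc(Sc2ncn[nH]2)c(O)c2ccccc12)c1ccc(Cl)cc1`: in this assay compound 3 gives 5520 nM.

Compound 3 stands lowest of the three numbers in this assay. Both other compounds lie beyond the scatter from it: the nearer one by a 7.6-fold lower number from compound 1 to compound 3 (0.88 log units; beyond the scatter), the further one by a 9.0-fold lower number from compound 2 to compound 3 (0.95 log units; beyond the scatter).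

Compound 4, `O=C(Nc1cc(Sc2ncn[nH]2)c(O)c2ccccc12)c1cccc(Cl)c1`, has the same atoms as compound 3 joined differently: 3-chlorophenyl in place of 4-chlorophenyl on a carbonyl carbon.

Within the data shown here, only one measured step touches the group on the carbonyl carbon, a 7.6-fold lower number from compound 1 to compound 3 (0.88 log units; beyond the scatter), and that step exchanged both the substituent and its place on the phenyl at once. It therefore cannot be split into a part for the chlorine and a part for its position. The step of a 9.0-fold lower number from compound 2 to compound 3 (0.95 log units; beyond the scatter) concerns the group on the sulfur and does not bear on the present change. Among the measured compounds shown here, no measured pair moves one substituent within the same phenyl. The expectation for compound 4 is therefore a small step, a 1.4-fold higher number from compound 3 to compound 4 (0.16 log units; within the scatter), not clearly beyond the scatter, with wide uncertainty in either direction. Compound 4 is estimated at 8000 nM in this assay, with a range from 2500 nM to 30000 nM.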

Compound 4, half-maximal inhibitory concentration: 85600 nM
Estimate against measurement, compound 4: 11-fold (1.03 log units) below; measured number above the stated range.
By their numbers in this assay, from the lowest: compound 3; then compounds 1, 2 and 4 (each within the scatter of the next, the first and the last beyond it).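

In this assay, moving the chlorine alone gives a 16-fold higher number from compound 3 to compound 4 (1.19 log units; beyond the scatter), with 3-chlorophenyl in place of 4-chlorophenyl on the carbonyl carbon; the place of the chlorine on this phenyl therefore matters on its own, with the atoms unchanged, which the earlier step could not separate from the exchange of substituent. With the substituent kept at the same place on the phenyl, chloro in place of methoxy gives a 2.0-fold higher number from compound 1 to compound 4 (0.31 log units; beyond the scatter), a modest step in the opposite direction to the earlier gain, so within these compounds chlorine lowers the number only as 4-chlorophenyl and compound 4 goes against any reading that chlorine on this phenyl helps in general. No measurement shown here accounts for this dependence on position.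

Still open, going by these compounds, is whether the same positional step holds with the 5-methyl-1,3,4-thiadiazol-2-yl group on the sulfur, since the position has been compared only with the triazole in place. Also open, on these data alone, is how the unsubstituted phenyl, or a bromo, an amine or a carboxylic acid in place of the chlorine, would stand against compound 3 and compound 4.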